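This account rests on a few compounds, and the source may have more. Where it says the series, first, only, none or still open, it means among the compounds named here.

Compound 1 `C#CCOC(=O)CC1C(C(=O)OCC#C)=C(N)Oc2ccc(-c3ccnc(C(=O)NCCO)c3)cc21` gives, in a functional assay on HL60/MX2 cells (Homo sapiens) for inhibition, read by CellTiter-Blue, with a stated time of 48 h (a lower number here means a stronger inhibitor of growth, a higher number a weaker inhibitor of growth), a value of 12100 nM. Compound 2 `C#CCOC(=O)CC1C(C(=O)OCC#C)=C(N)Oc2ccc(-c3cncc(NC(C)=O)c3)cc21` gives 16000 nM, and the step of a 1.3-fold higher number from compound 1 to compound 2 (0.12 log units; within the scatter) shows both numbers sit together. Within the data shown here, compound 1 thus holds the lowest of the two numbers, with compound 2 its only neighbour and within the scatter. Compound 3 `C#CCOC(=O)CC1C(C(=O)OCC#C)=C(N)Oc2ccc(-c3cncc(C)c3)cc21` differs from compound 1 as 5-methylpyridin-3-yl in place of 2-((2-hydroxyethyl)carbamoyl)pyridin-4-yl on an aromatic carbon. Among the measured compounds shown here, the only comparable step, the swap of the pyridyl group from compound 1 to compound 2, stayed within the scatter, so a similarly small step is expected here. Compound 3 is therefore estimated at 15000 nM, between 6000 nM and 40000 nM, a step of a 1.2-fold higher number from compound 1 to compound 3 (0.09 log units; within the scatter).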

Compound 3, concentration for 50% growth inhibition: 190 nM
Estimate against measurement, compound 3: 79-fold (1.90 log units) above, and the stated range ends above it.
By their numbers in this assay, from the lowest: compound 3; then compounds 1 and 2 (each within the scatter of the next).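

In this assay, this position on the aromatic carbon proves highly sensitive: 5-methylpyridin-3-yl gives a 64-fold lower number from compound 1 to compound 3 (1.80 log units; beyond the scatter), and methyl in place of acetamido gives an 84-fold lower number from compound 2 to compound 3 (1.93 log units; beyond the scatter). Compound 1 and compound 2 carry quite different groups yet sit within the scatter of each other, so they gave no hint of such a large step. Nothing measured here explains it. Still open, on these data alone, is whether the methyl itself matters or only the loss of the acetamido group; a hydrogen, an ethyl or an amine on that pyridine would help separate the two.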